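This account rests on a few compounds, and the source may have more. Where it says the series, first, only, none or still open, it means among the compounds named here.

Compound 3 `N#Cc1ccc(Cn2c(=O)n(C3OC(CO)[C@@H](O)[C@H]3O)c3nc(N)nc(O)c32)cc1` gives 0% in a functional assay on YAC-1 cells (Mus musculus) (on this read-out lower numbers stand for smaller maximal responses and higher numbers for larger maximal responses), the lowest of the three numbers measured. Compound 2 `N#Cc1cccc(Cn2c(=O)n(C3OC(CO)[C@@H](O)[C@H]3O)c3nc(N)nc(O)c32)c1` gives 11% and compound 1 `Nc1nc(O)c2c(n1)n(C1OC(CO)[C@@H](O)[C@H]1O)c(=O)n2Cc1ccc(Cl)c(Cl)c1` gives 15%; the steps of a number 15 percentage points lower from compound 1 to compound 3 (beyond the scatter) and a number 11 percentage points lower from compound 2 to compound 3 (beyond the scatter) both lie beyond the scatter, whereas a number 4 percentage points lower from compound 1 to compound 2 (within the scatter) lies within it. Compound 4 `NC(=O)Cn1c(=O)n(C2OC(CO)[C@@H](O)[C@H]2O)c2nc(N)nc(O)c21` differs from compound 3 by carbamoyl in place of 4-cyanophenyl on a saturated chain carbon bound to an aromatic nitrogen. Every measured step exchanges one aryl group for another on that saturated chain carbon, and none removes the ring in favour of a carbamoyl, so they bear on this change only loosely, showing modest shifts at most. Since compound 3 already sits at the bottom of the scale, little room for a fall remains. Compound 4 is therefore expected to change by a number 5 percentage points higher from compound 3 to compound 4 (within the scatter). The estimate for compound 4 is 5%, between 0% and 20%.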

Compound 4, largest response reached (reported as maximal response), in percent of the reference or control that the assay uses: 42%
For compound 4 the middle estimate is 37 percentage points below the measured one, and the stated range ends below it.
By their numbers in this assay, from the lowest: compound 3; then compounds 2 and 1 (each within the scatter of the next); then compound 4.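

In this assay carbamoyl on the saturated chain carbon bound to an aromatic nitrogen gives a number 42 percentage points higher from compound 3 to compound 4 (beyond the scatter) and a number 31 percentage points higher from compound 2 to compound 4 (beyond the scatter) and also a number 27 percentage points higher from compound 1 to compound 4 (beyond the scatter) in the three comparisons. The aryl exchanges had shown only low numbers at this position, whereas this change away from an aromatic ring gives the highest number of the four compounds. Nothing available accounts for this rise. As far as these compounds go, whether it belongs to the carbamoyl itself or to the loss of the ring stays open, as does what a carboxylic acid or an amine would give at this place.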